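Swapping the ring on the sulfur: pyrimidine to methylthiadiazole

This account rests on a few compounds, and the source may have more. Where it says the series, first, only, none or still open, it means among the compounds named here.

Three compounds share a core and differ only in the ring attached to a sulfur. Compound 3 `Cc1ccc(-c2cs/c(=N/NC(=O)CSc3ncccn3)n2-c2ccccc2)cc1` carries a pyrimidin-2-yl there, and in a functional assay on C6 cells (Rattus norvegicus) for cytotoxicity, read by MTT assay, with a stated time of 24 h, tested at 50 ug/mL (a higher number here means a weaker effect of the compound at the concentration tested, a lower number a stronger effect), compound 3 gives 64.4%. Compound 2 `Cc1ccc(-c2cs/c(=N/NC(=O)CSc3nnnn3-c3ccccc3)n2-c2ccccc2)cc1` carries a 1-phenyl-1H-tetrazol-5-yl, and in this assay compound 2 gives 29.5%. Compound 1 `Cc1nnc(SCC(=O)N/N=c2/scc(-c3ccccc3)n2-c2ccccc2)s1` carries a 5-methyl-1,3,4-thiadiazol-2-yl on a core whose other ring lacks the methyl, and in this assay compound 1 gives 63.9%. Among the measured compounds shown here, compound 3 thus stands at the top of the three numbers; compound 1 sits within the scatter of it, while compound 2 lies well below, the one step that is known being a number 34.9 percentage points higher from compound 2 to compound 3 (beyond the scatter).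

Compound 4 `Cc1ccc(-c2cs/c(=N/NC(=O)CSc3nnc(C)s3)n2-c2ccccc2)cc1` is not yet measured. It differs from compound 3 by 5-methyl-1,3,4-thiadiazol-2-yl in place of pyrimidin-2-yl on a sulfur. For the measured compounds named here, no measured step covers exactly this exchange. The nearest guide is compound 1, which carries the same 5-methyl-1,3,4-thiadiazol-2-yl and gives a number indistinguishable from compound 3. On that basis the change is expected to be a number 4.4 percentage points lower from compound 3 to compound 4 (within the scatter), that is, nothing beyond the scatter. Compound 4 is therefore estimated at 60%, within a range from 42% to 78%.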

Compound 4, a percentage reported as activity, at one concentration (the size of the read-out at that concentration, not a potency): 40.6%
The estimate for compound 4 lay 19.4 percentage points above the measured number, and the stated range ends above it.
By their numbers in this assay, from the lowest: compound 2; then compound 4; then compounds 1 and 3 (each within the scatter of the next).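

Exchanging pyrimidin-2-yl for 5-methyl-1,3,4-thiadiazol-2-yl on the sulfur gives a number 23.8 percentage points lower from compound 3 to compound 4 (beyond the scatter) in this assay, a stronger effect, while 5-methyl-1,3,4-thiadiazol-2-yl in place of 1-phenyl-1H-tetrazol-5-yl gives a number 11.1 percentage points higher from compound 2 to compound 4 (beyond the scatter), a weaker one, so the ring at this position clearly sets the read-out and all three rings on this core can be told apart. The methyl on the core matters as well: with the same ring on the sulfur, adding it in place of hydrogen on an aromatic carbon gives a number 23.3 percentage points lower from compound 1 to compound 4 (beyond the scatter), so a result for a ring on one core does not carry over unchanged to the other. Nothing measured here explains either change.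

Going by these compounds, how pyrimidin-2-yl or 1-phenyl-1H-tetrazol-5-yl would respond to removing that core methyl remains open, so it is unknown whether the methyl has the same effect with every ring. It is also open whether a small group such as an amine or a chlorine in place of the methyl on the 5-methyl-1,3,4-thiadiazol-2-yl would strengthen or weaken the effect, and a single concentration gives no potency for any of these compounds.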